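The compounds below may be only part of what the source reports. "The series", "measured", "known", "first", "only" and "open" are said of these compounds alone.

In an ADME assay on the whole organism (Mus musculus, strain ICR) for pharmacokinetics, at a dose of 50 mg/kg by the oral route (on this read-out lower numbers stand for lower exposure and higher numbers for higher exposure at the dose given), three compounds sharing one core have been measured. Compound 1 `N#CC1CC(=O)N(c2cnn3c2CN(C(=O)Nc2cc(F)c(F)c(F)c2)C(C2CC2)C3)C1` gives 14400 nM, compound 2 `O=C1CC(c2ncco2)CN1c1cnn2c1CN(C(=O)Nc1cc(F)c(F)c(F)c1)C(C1CC1)C2` gives 18000 nM, and compound 3 `O=C1CC(c2ncccn2)CN1c1cnn2c1CN(C(=O)Nc1cc(F)c(F)c(F)c1)C(C1CC1)C2` gives 12000 nM. Compound 3 therefore stands level with the other two, within the usual scatter of both. The next compound, compound 4 `Cc1nc(C2CC(=O)N(c3cnn4c3CN(C(=O)Nc3cc(F)c(F)c(F)c3)C(C3CC3)C4)C2)no1`, differs from compound 3 in one group: 5-methyl-1,2,4-oxadiazol-3-yl in place of pyrimidin-2-yl on a saturated ring carbon. In words, 5-methyl-1,2,4-oxadiazol-3-yl stands in place of pyrimidin-2-yl on a saturated ring carbon. Three measured swaps on that same carbon bear on this change. Putting 1,3-oxazol-2-yl in place of cyano gave a 1.3-fold higher number from compound 1 to compound 2 (0.10 log units; within the scatter), pyrimidin-2-yl in place of cyano gave a 1.2-fold lower number from compound 1 to compound 3 (0.08 log units; within the scatter), and pyrimidin-2-yl in place of 1,3-oxazol-2-yl gave a 1.5-fold lower number from compound 2 to compound 3 (0.18 log units; within the scatter). All three stayed within the scatter, although none involved the incoming group itself. No step beyond the scatter is therefore expected in this assay. The expected change is a 1.2-fold higher number from compound 3 to compound 4 (0.07 log units; within the scatter). The estimate for compound 4 is 14000 nM, with an expected range of 7000 nM to 28000 nM.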

Compound 4, maximal plasma concentration: 7710 nM
Compound 4: the middle estimate sits 1.8-fold (0.26 log units) above what was measured; low and high end bracket the measured number.
By their numbers in this assay, from the lowest: compounds 4, 3, 1 and 2 (each within the scatter of the next, the first and the last beyond it).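

In this assay, within the data shown here, 5-methyl-1,2,4-oxadiazol-3-yl in place of 1,3-oxazol-2-yl gives the first step on this saturated ring carbon that passes the scatter, a modest one: a 2.3-fold lower number from compound 2 to compound 4 (0.37 log units; beyond the scatter). Among these compounds, the other two new steps stay within the scatter, a 1.6-fold lower number from compound 3 to compound 4 (0.19 log units; within the scatter) and a 1.9-fold lower number from compound 1 to compound 4 (0.27 log units; within the scatter), so compound 2 and compound 4 are the only pair among the four compounds that the read-out separates. No evidence is available on what lies behind this separation. The compounds shown leave open whether an amine or a carboxylic acid on this carbon would give a larger step. They also leave open whether the same swap would give a step of similar size on a different core.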